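A few compounds are considered here, and "the series" means these few. Any claim that something is new, unique, unknown or untested is made for them only; others in the source may bear on it.

In a functional assay on MDA-MB-231 cells (Homo sapiens) for antiproliferative activity, read by MTT assay, with a stated time of 72 h (on this read-out higher numbers stand for weaker inhibition and lower numbers for stronger inhibition), compound 1 (`O=C(Nc1ccc(Cl)cc1)Nc1cccc(-c2nc(-c3ccc(NC(=O)c4cccnc4)cc3Cl)no2)c1`) gives > 10000 nM, which is a limit of the assay and not a number. For the measured compounds named here, compound 2 (`Cc1ccc(NC(=O)Nc2cccc(-c3nc(-c4ccc(NC(=O)c5cccnc5)cc4Cl)no3)c2)cc1`) gives 3500 nM, the only actual number so far. Compound 3 (`O=C(Nc1cccc(-c2nc(-c3ccc(NC(=O)c4cccnc4)cc3Cl)no2)c1)Nc1ccc(Cl)c(C(F)(F)F)c1`) has not yet been measured. It differs from compound 2 by 4-chloro-3-(trifluoromethyl)phenyl in place of 4-methylphenyl on an amide-type nitrogen, with 4-chloro-3-(trifluoromethyl)phenyl in place of 4-methylphenyl on an amide-type nitrogen. Going by the values given here, only one measured step bears on this change: methyl in place of chloro on an aromatic carbon gave an at least 2.8-fold lower number from compound 1 to compound 2 (0.45 log units; beyond the scatter), which lies beyond the scatter. Among the compounds with values here, compound 3 gives up that methyl and carries a chloro again, so on the evidence of an at least 2.8-fold lower number from compound 1 to compound 2 (0.45 log units; beyond the scatter) a modest rise in the number is expected, although no measured step covers the trifluoromethyl. The expected change is a 2.0-fold higher number from compound 2 to compound 3 (0.30 log units; within the scatter). For compound 3 the estimate is 7000 nM, with an expected range of 1500 nM to 30000 nM.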

Compound 3, half-maximal inhibitory concentration: 1900 nM
The estimate for compound 3 lay 3.7-fold (0.57 log units) above the measured number; the measured number falls inside the stated range.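

In this assay, 4-chloro-3-(trifluoromethyl)phenyl in place of 4-methylphenyl on the amide-type nitrogen gives a 1.8-fold lower number from compound 2 to compound 3 (0.27 log units; within the scatter), so this change does not separate the two compounds. Adding a trifluoromethyl to the aromatic ring, with the chloro kept, gives an at least 5.2-fold lower number from compound 1 to compound 3 (0.72 log units; beyond the scatter), which shows that a chloro on this phenyl does not by itself go with the weak result of compound 1. Compound 1 stands at a limit of the assay and not at a number, so the size of that step is only a bound: the limit of > 10000 nM in this assay, at which 1 of the 3 values shown sits.

The compounds shown leave open how a phenyl carrying the trifluoromethyl without the chloro would compare with compound 3. They also leave open how a different group on this phenyl, such as a methoxy group or an amine, would read.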